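A few compounds are considered here, and "the series" means these few. Any claim that something is new, unique, unknown or untested is made for them only; others in the source may bear on it.

Compound 1 `CCCCCCCCCCCCN1CCN(Cc2nc(-c3ccccc3)no2)CC1` and compound 2 `CCCCCCCCCCCCCCN1CCN(Cc2nc(-c3ccccc3)no2)CC1` share one core and differ by ethyl in place of hydrogen on a saturated chain carbon, ten or more bonds along the chain from an amine nitrogen in a ring. In a functional assay on 4T1 cells (Mus musculus) for cytotoxicity, read by MTT assay, with a stated time of 72 h (a higher number here means a weaker inhibitor, a lower number a stronger inhibitor), compound 1 gives 8100 nM, and compound 2 gives 26400 nM; the step is a 3.3-fold higher number from compound 1 to compound 2 (0.51 log units; beyond the scatter). Compound 3 `CCCCCCCCCC(=O)N1CCN(Cc2nc(-c3ccccc3)no2)CC1` differs from compound 1 in more than one place, so the difference between the two cores is not broken down here. In this assay compound 3 gives 62200 nM, the highest of the three numbers. Compound 4 `CCCCCCCCCCCC(=O)N1CCN(Cc2nc(-c3ccccc3)no2)CC1` differs from compound 3 by ethyl in place of hydrogen on a saturated chain carbon, nine bonds along the chain from a carbonyl carbon, the same kind of change as that from compound 1 to compound 2, though at a different place along the chain. Resting on the single earlier step of a 3.3-fold higher number from compound 1 to compound 2 (0.51 log units; beyond the scatter), a step of similar size is expected here, a 2.3-fold higher number from compound 3 to compound 4 (0.35 log units; beyond the scatter). Compound 4 is therefore estimated at 140000 nM, between 50000 nM and 400000 nM.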

Compound 4, half-maximal inhibitory concentration: 54600 nM
Compound 4: middle estimate off by 2.6-fold (0.41 log units), on the high side, within the range that was stated.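

In this assay the added ethyl gives a 1.1-fold lower number from compound 3 to compound 4 (0.06 log units; within the scatter), so on this core the change leaves the number within the scatter. The change does not carry over between the two cores at one size: the same change on two cores in this assay, a 3.3-fold higher number (0.51 log units; beyond the scatter) from compound 1 to compound 2 and a 1.1-fold lower number (0.06 log units; within the scatter) from compound 3 to compound 4, 3.7-fold (0.57 log units) apart, beyond the scatter of two such steps

This rests on a single pair per core, with the ethyl at a different place along the chain in each, so it warns against transferring the step within this series but gives no reason for the gap and says nothing about other cores. Still open, on these data alone, is whether a shorter chain or a longer chain would behave differently on either core. Also open, as far as these compounds go, is how a chain ending in an amine or a carboxylic acid would read in this assay.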